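The compounds below may be only part of what the source reports. "The series", "measured", "known", "first", "only" and "open" are said of these compounds alone.

Measured in a functional assay on K562/A02 cells (Homo sapiens) for antiproliferative activity, read by MTT assay; on this read-out lower numbers stand for stronger inhibition and higher numbers for weaker inhibition:
- compound 1 `Cc1ccc(/C(=N/NC(=S)NCCCCCC(=O)NO)c2ccccc2)cc1` gives 3150 nM
- compound 2 `O=C(CCCCCNC(=S)N/N=C(\c1ccccc1)c1ccccc1[N+](=O)[O-])NO` gives 1310 nM
- compound 3 `O=C(CCCCCNC(=S)N/N=C(\c1ccccc1)c1ccc([N+](=O)[O-])cc1)NO` gives 4530 nM

Compound 3 carries the highest number of the three, but it does not stand alone at that end. The data show a 1.4-fold higher number from compound 1 to compound 3 (0.16 log units; within the scatter), whereas they show a 3.5-fold higher number from compound 2 to compound 3 (0.54 log units; beyond the scatter). The next compound, compound 4 `COc1ccccc1/C(=N/NC(=S)NCCCCCC(=O)NO)c1ccccc1`, has not yet been measured. The change leading to it is 2-methoxyphenyl in place of 4-nitrophenyl on a carbon with a double bond to nitrogen.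

Among the measured compounds shown here, no measured step makes this exact exchange. For the measured compounds named here, the nearest evidence is compound 2, the only measured compound whose group bears the same 2 numbering as the incoming one. Two steps set it apart (a 2.4-fold lower number from compound 1 to compound 2 (0.38 log units; beyond the scatter), and the step to compound 3 given above), and both are modest. However, that group is 2-nitrophenyl rather than 2-methoxyphenyl, and a single compound makes a thin basis, so only part of that gap is expected to carry over. A modest move toward a lower number is therefore expected, close to the edge of the scatter. The expected step is a 2.1-fold lower number from compound 3 to compound 4 (0.31 log units; beyond the scatter) in this assay. For compound 4 the estimated value is 2200 nM, with an expected range from 1000 nM to 4800 nM.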

Compound 4, half-maximal inhibitory concentration: 2910 nM
Beside the measured number, compound 4's estimate is 1.3-fold (0.12 log units) below it; measured number inside the range.
By their numbers in this assay, from the lowest: compound 2; then compounds 4, 1 and 3 (each within the scatter of the next).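

In this assay, the 2-methoxyphenyl group on a carbon with a double bond to nitrogen cannot be told apart from the 4-nitrophenyl group, with a 1.6-fold lower number from compound 3 to compound 4 (0.19 log units; within the scatter), or from the 4-methylphenyl group, with a 1.1-fold lower number from compound 1 to compound 4 (0.03 log units; within the scatter). The exchange of nitro for methoxy on an aromatic carbon is different, as it gives a 2.2-fold higher number from compound 2 to compound 4 (0.35 log units; beyond the scatter); the shared 2 numbering therefore does not by itself bring compound 4 level with compound 2, and of the four compounds only compound 2, with its 2-nitrophenyl group, stands clear of all the others. Nothing measured on these compounds offers a reason for that separation.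

The compounds shown leave open whether the standing of compound 2 belongs to the nitro group alone, or whether a 2-aminophenyl or 2-cyanophenyl group on the same carbon would separate from compound 4 in the same way. They also leave open whether a 4-methoxyphenyl group would give a number apart from that of the 2-methoxyphenyl group in compound 4.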